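Compound 2 to compound 3: acetyl for benzyl

This account rests on a few compounds, and the source may have more. Where it says the series, first, only, none or still open, it means among the compounds named here.

In a functional assay on HeLa cells (Homo sapiens) for cytotoxicity (on this read-out higher numbers stand for weaker inhibition and lower numbers for stronger inhibition), compound 1 `Nc1[nH]nc2nncc(-c3ccccc3)c12` gives > 100000 nM, a limit of the assay and not a number. Compound 2 `Nc1nn(Cc2ccccc2)c2nnc(-c3ccccc3)c(-c3ccccc3)c12` gives > 100000 nM, again only a limit. Among the compounds with values here, the series therefore stands at the limit of > 100000 nM in this assay, at which 2 of the 2 values shown sit, and no measured step is available to size a structural change.

Compound 3 `CC(=O)n1nc(N)c2c(-c3ccccc3)c(-c3ccccc3)nnc21` carries acetyl in place of benzyl on an aromatic nitrogen. No step beyond the scatter is expected in this assay, and a further reading at the limit is likely. This expectation rests on compound 2, whose only reading is the limit > 100000 nM. The estimated change is a number no higher from compound 2 to compound 3 (the limit leaves the size open). For compound 3, the estimated value is 100000 nM, with an expected range of 30000 nM to 300000 nM.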

Compound 3, half-maximal inhibitory concentration: > 100000 nM
Compound 3: a limit, no number (the forecaster's own chance of this, stated with the estimate: 75%); the middle value sits exactly at the limit.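

Compound 2 and compound 3 both read as limits in this assay, so no step can be read for acetyl in place of benzyl on an aromatic nitrogen. The compounds shown leave open whether any change to the shared core gives a measurable value: the limit of > 100000 nM in this assay, at which 3 of the 3 values shown sit.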